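A few compounds are considered here, and "the series" means these few. Any claim that something is new, unique, unknown or untested is made for them only; others in the source may bear on it.

Measured so far:
Compound 1, `COc1nn2cc(-c3cc4ccccc4o3)nc2s1`: 80%
Compound 2, `COc1cc(OCc2cccc(Sc3ccccc3)c2)c2cc(-c3cn4nc(OC)sc4n3)oc2c1`: 80%

Both numbers come from an ADME assay on microsomes from liver (Homo sapiens) for metabolic stability, with a stated time of 10 min; on this read-out lower numbers stand for a less stable compound and higher numbers for a more stable compound. On this read-out compound 2 stands level with compound 1, the difference falling inside the scatter of repeat measurements. The next compound, compound 3 `COc1cc(OCc2cccc(OCc3ccccc3)c2)c2cc(-c3cn4nc(OC)sc4n3)oc2c1`, carries one change against compound 2: benzyloxy in place of phenylsulfanyl on an aromatic carbon. Going by the values given here, no measured pair shows how such an exchange moves the read-out, so only a small step is expected in this assay, most likely none beyond the scatter and if anything a slight drop. The step expected is a number 8 percentage points lower from compound 2 to compound 3 (within the scatter). Compound 3 is thus expected at 72%, with a range from 50% to 90%.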

Compound 3, percent of the compound remaining: 85%
Compound 3: the middle estimate sits 13 percentage points below what was measured, within the range that was stated.
By their numbers in this assay, from the lowest: compounds 1, 2 and 3 (each within the scatter of the next).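

In this assay, going by these compounds alone, the exchange of phenylsulfanyl for benzyloxy on this aromatic carbon gives a number 5 percentage points higher from compound 2 to compound 3 (within the scatter) and is the first single-place change to be read. At this place, meta to a large group, the two groups therefore cannot be told apart on this read-out, even though benzyloxy brings oxygen in place of sulfur and one more heavy atom. Nothing shown here explains this result. Still open, on these data alone, is how an amine, a carboxylic acid or a longer alkyl chain at this place would stand in this assay, and whether the same exchange would read alike on another core.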